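The source may hold more compounds than are shown below. What is called first, only, known or untested is meant among the compounds shown, and "the series" means these compounds.

In a functional assay on A20 cells (Mus musculus) for inhibition, with stated times of 1 h, 16 h and 24 h (a higher number here means a weaker inhibitor, a lower number a stronger inhibitor), compound 1 `N#CCNC(=O)[C@@H]1CC(F)(F)C[C@H]1C(=O)N1CCOCC1` gives 925 nM, while compound 2 `N#CC1(NC(=O)[C@@H]2C[C@@H](S(=O)(=O)c3ccccc3)C[C@H]2C(=O)N2CC3(COC3)C2)CC1` gives 248 nM, the lower of the two numbers by more than the usual scatter. Compound 3 `N#CC1(NC(=O)[C@@H]2C[C@@H](S(=O)(=O)c3ccccc3)C[C@H]2C(=O)N2CCCC2)CC1` keeps the rest of compound 2 and changes one group on a carbonyl carbon: a group of 5 heavy atoms (4 carbon, 1 nitrogen; one five-membered non-aromatic ring with 1 hetero atom) in place of a group of 7 heavy atoms (5 carbon, 1 nitrogen, 1 oxygen; 2 four-membered non-aromatic rings with 1 hetero atom each), on a carbonyl carbon. Among the measured compounds shown here, the two measured compounds differ in more than one place, so no measured step guides this change. The expected 1.1-fold lower number from compound 2 to compound 3 (0.05 log units; within the scatter) in this assay is small, with no shift beyond the scatter. The estimated value for compound 3 is 220 nM, with a likely range from 80 nM to 600 nM.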

Compound 3, half-maximal inhibitory concentration: 29 nM
The estimate for compound 3 lay 7.6-fold (0.88 log units) above the measured number; measured number outside the range, below it.
By their numbers in this assay, from the lowest: compound 3; then compound 2; then compound 1.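

In this assay the group on the carbonyl carbon proves to matter: pyrrolidin-1-yl in place of the group with two four-membered rings gives an 8.6-fold lower number from compound 2 to compound 3 (0.93 log units; beyond the scatter) with the rest of the molecule unchanged. Among the compounds shown here, this is the only comparison here that differs in one place, so it is the only direct sign that this position affects the read-out. No measured evidence gives a reason for the step. The compounds shown cannot separate the roles of ring size, the ring oxygen and the number of rings. Piperidin-1-yl or diethylamino on the same carbonyl carbon would test how specific the pyrrolidin-1-yl result is.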